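Series notes: fluoro for methoxy, toward compound 4

The source may hold more compounds than are shown below. What is called first, only, known or untested is meant among the compounds shown, and "the series" means these compounds.

Compound 1, `CCCCCCCCS(=O)(=O)Nc1cc(-c2ccc(Cl)cc2)ccc1C(=O)O`, in an assay on mitochondria (strain BALB/c) for inhibition of glycerol-3-phosphate acyltransferase 1, mitochondrial (Mus musculus), read by scintillation counting, with a stated time of 10 min (a higher number here means a weaker inhibitor, a lower number a stronger inhibitor), gives 18100 nM.
Compound 2, `CCCCCCCCS(=O)(=O)Nc1cc(-c2ccccc2-c2ccccc2)ccc1C(=O)O`, in this assay gives 17100 nM.
Compound 3, `CCCCCCCCS(=O)(=O)Nc1cc(-c2ccccc2OC)ccc1C(=O)O`, in this assay gives 16100 nM.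

Compound 3 carries the lowest of the three numbers, but its separation from the others is small: a 1.1-fold lower number from compound 1 to compound 3 (0.05 log units; within the scatter) and a 1.1-fold lower number from compound 2 to compound 3 (0.03 log units; within the scatter) both fall within the scatter, so the three compounds are indistinguishable on these data.

Compound 4, `CCCCCCCCS(=O)(=O)Nc1cc(-c2ccccc2F)ccc1C(=O)O`, is the next step: fluoro in place of methoxy on an aromatic carbon. The two measured changes to the pendant ring at this carbon, a 1.1-fold lower number from compound 2 to compound 3 (0.03 log units; within the scatter) and a 1.1-fold lower number from compound 1 to compound 3 (0.05 log units; within the scatter), left the number essentially unchanged, so a single-atom swap at the same place is expected to do likewise in this assay. Compound 4 is therefore expected near 16000 nM, plausibly between 8000 nM and 32000 nM, a step of a 1.0-fold lower number from compound 3 to compound 4 (0.00 log units; within the scatter) that is expected to stay within the scatter.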

Compound 4, half-maximal inhibitory concentration: 47200 nM
Beside the measured number, compound 4's estimate is 3.0-fold (0.47 log units) below it, outside the stated range (above it).
By their numbers in this assay, from the lowest: compounds 3, 2 and 1 (each within the scatter of the next); then compound 4.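

Fluoro at this place sets compound 4 apart in this assay, with all three steps modest: a 2.9-fold higher number from compound 3 to compound 4 (0.47 log units; beyond the scatter), a 2.8-fold higher number from compound 2 to compound 4 (0.44 log units; beyond the scatter) and a 2.6-fold higher number from compound 1 to compound 4 (0.42 log units; beyond the scatter). The pendant ring can therefore register in the number, although methoxy, phenyl and the 4-chlorophenyl ring gave no separation among themselves. No measured evidence bears on this shift.

Going by these compounds, it remains open whether 2-chlorophenyl or 2-methylphenyl would read with compound 4 or with compound 3. Whether a hydroxy group or an amine at the same place would do either is also unresolved.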